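The compounds below may be only part of what the source reports. "The series", "measured", "known", "first", "only" and "open" are said of these compounds alone.

In a functional assay on HCT-116 cells (Homo sapiens) for antiproliferative activity, read by MTT assay, with a stated time of 48 h (on this read-out lower numbers stand for stronger inhibition and higher numbers for weaker inhibition), compound 1 `O=C(Nc1cccc(/C=C/C(=O)c2nc3ccccc3[nH]2)c1)c1cccc(Br)c1` gives 1560 nM, and compound 2 `Cc1ccccc1C(=O)Nc1cccc(/C=C/C(=O)c2nc3ccccc3[nH]2)c1` gives 1870 nM. Among the compounds with values here, compound 2 thus stands with the higher of the two numbers so far, though the step of a 1.2-fold higher number from compound 1 to compound 2 (0.08 log units; within the scatter) is within the scatter. Compound 3 `O=C(Nc1cccc(/C=C/C(=O)c2nc3ccccc3[nH]2)c1)c1cc(Cl)cc(Cl)c1` differs from compound 2 by 3,5-dichlorophenyl in place of 2-methylphenyl on a carbonyl carbon. Within the data shown here, the only step that bears on this change is the one from compound 1 to compound 2, which was within the scatter, so no shift beyond the scatter is expected in this assay. The estimated step is therefore a 1.3-fold lower number from compound 2 to compound 3 (0.13 log units; within the scatter) for compound 3. Compound 3 is expected to give about 1400 nM, in a range from 600 nM to 3500 nM.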

Compound 3, half-maximal inhibitory concentration: 1650 nM
For compound 3 the middle estimate is 1.2-fold (0.07 log units) below the measured one; the measured number falls inside the stated range.
By their numbers in this assay, from the lowest: compounds 1, 3 and 2 (each within the scatter of the next).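

In this assay, the step of a 1.1-fold lower number from compound 2 to compound 3 (0.05 log units; within the scatter) and the step of a 1.1-fold higher number from compound 1 to compound 3 (0.02 log units; within the scatter) both lie within the scatter. At this place on the carbonyl carbon, 3,5-dichlorophenyl, with its two chlorine atoms, therefore cannot be told apart from either 2-methylphenyl or 3-bromophenyl. Within the data shown here, three differently substituted phenyl groups now give matching numbers, where earlier only one pair could be compared. From the compounds shown here alone, whether a phenyl group carrying an amine or a carboxylic acid, or a longer alkyl chain in place of the phenyl ring, would also leave the number unchanged remains open. Nothing measured here offers an explanation for this result.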